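The source may hold more compounds than are shown below. What is called first, only, known or untested is meant among the compounds shown, and "the series" means these compounds.

Going by the values given here, in a functional assay on SK-BR-3 cells (Homo sapiens) for antiproliferative activity, read by CCK-8 assay, with a stated time of 72 h (a lower number here means a stronger inhibitor, a higher number a weaker inhibitor), three compounds that share one core and differ in a single aromatic group have numbers so far. Compound 1 (`Cc1cc(Nc2cc(N3CCN(C)CC3)nc(Nc3ccc(S(N)(=O)=O)cc3)n2)n[nH]1`) , with 4-sulfamoylphenyl, gives 15900 nM. Compound 2 (`COc1cccc(Nc2nc(Nc3cc(C)[nH]n3)cc(N3CCN(C)CC3)n2)c1`) , with 3-methoxyphenyl, gives 11300 nM, a change that stays within the scatter: a 1.4-fold lower number from compound 1 to compound 2 (0.15 log units; within the scatter). Compound 3 (`Cc1cc(Nc2cc(N3CCN(C)CC3)nc(Nc3cccc(Cl)c3)n2)n[nH]1`) , with 3-chlorophenyl, gives 2290 nM, the lowest of the three numbers.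

Compound 4 (`Cc1cc(Nc2cc(N3CCN(C)CC3)nc(Nc3ccc(C#N)cc3)n2)n[nH]1`) has not been measured. It carries 4-cyanophenyl in place of 3-chlorophenyl on a nitrogen on an aromatic ring. Among the compounds with values here, no nitrile-bearing compound has a number yet, so the guide is what happened at this same place. The two measured steps that end at compound 3 are both modest, a 6.9-fold lower number from compound 1 to compound 3 (0.84 log units; beyond the scatter) and a 4.9-fold lower number from compound 2 to compound 3 (0.69 log units; beyond the scatter). Giving up the 3-chlorophenyl group in compound 1 and compound 2 thus goes with a higher number, and a modest rise is expected in this assay. The expected step is a 3.3-fold higher number from compound 3 to compound 4 (0.52 log units; beyond the scatter). For compound 4 the estimate is 7500 nM, with an expected range from 2500 nM to 20000 nM.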

Compound 4, half-maximal inhibitory concentration: 883 nM
Estimate against measurement, compound 4: 8.5-fold (0.93 log units) above; the whole stated range lies above it.
By their numbers in this assay, from the lowest: compound 4; then compound 3; then compounds 2 and 1 (each within the scatter of the next).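

In this assay, the 4-cyanophenyl group on this nitrogen does better than 3-chlorophenyl, a 2.6-fold lower number from compound 3 to compound 4 (0.41 log units; beyond the scatter), so the 3-chlorophenyl group no longer gives the lowest number at this place. The wider steps, a 13-fold lower number from compound 2 to compound 4 (1.11 log units; beyond the scatter) and an 18-fold lower number from compound 1 to compound 4 (1.26 log units; beyond the scatter), are large, and the second of them exchanges only sulfamoyl for cyano on an aromatic carbon, so that single group separates the two ends of this short series. No measurement here explains why the nitrile-bearing compound gives the lowest number.

The compounds shown leave open whether a trifluoromethyl group, an amide or a carboxylic acid in place of the cyano would lower the number further. They also leave open whether the 4-cyanophenyl gain would hold if another part of the shared core were changed.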